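The source may hold more compounds than are shown below. What is called first, only, known or untested is meant among the compounds shown, and "the series" means these compounds.

Measured in a functional assay (blood) for inhibition, with Homo sapiens as the target; a lower number here means a stronger inhibitor, a higher number a weaker inhibitor:
- Compound 1 `CC(C)(C)Sc1c(CC(C)(C)C(=O)O)n(Cc2ccc(Cl)cc2)c2ccc(OCc3cc4ccccc4cn3)cc12`: > 3000 nM
- Compound 2 `CC(C)(C)Sc1c(CC(C)(C)C(=O)O)n(Cc2ccc(Cl)cc2)c2ccc(OCc3ccncc3)cc12`: > 3000 nM

Compound 2 stands at > 3000 nM, which is a limit of the assay and not a number. Compound 1 also gives only a limit, so the picture is simple: the limit of > 3000 nM in this assay, at which 2 of the 2 values shown sit. Neither compound has a true half-maximal concentration that can be compared with the other.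

Within the data shown here, the next compound is compound 3 `CC(C)(C)Sc1c(CC(C)(C)C(=O)O)n(Cc2ccc(Cl)cc2)c2ccc(OCc3cnccn3)cc12`, which keeps the shared core and changes only one ring: pyrazin-2-yl in place of pyridin-4-yl on a saturated chain carbon bound to an oxygen on an aromatic ring. Among the measured compounds shown here, one measured step bears on this place, namely a step that the two limits leave unreadable from compound 1 to compound 2. That step has no size, so it cannot be used to scale the new change. For the measured compounds named here, it shows only that two different rings at this place both ended at the limit.

The expectation is therefore modest, with no clear gain and no direction that the data can support. The expected change, a step that the limit leaves unreadable from compound 2 to compound 3, is an estimate with little behind it. For compound 3 the estimated value is 3500 nM, with an expected range from 1000 nM to 10000 nM.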

Compound 3, half-maximal inhibitory concentration: 400 nM
Estimate against measurement, compound 3: 8.8-fold (0.94 log units) above; the measured number lies below the stated range.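

In this assay, among these compounds, this position can carry measurable activity: pyrazin-2-yl in place of pyridin-4-yl gives an at least 7.5-fold lower number from compound 2 to compound 3 (0.87 log units; beyond the scatter), the first step at this place that can be read at all. Pyrazin-2-yl in place of isoquinolin-3-yl gives an at least 7.5-fold lower number from compound 1 to compound 3 (0.87 log units; beyond the scatter), and both steps start from a limit and not from a number, so their full size stays unknown, which is the main caution in reading them: the limit of > 3000 nM in this assay, at which 2 of the 3 values shown sit.

Activity here also turns on a small change, as pyridin-4-yl and pyrazin-2-yl are both six-membered aromatic rings with 6 heavy atoms, and they differ in holding 1 and 2 nitrogen atoms.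

The two rings differ both in the number of nitrogen atoms and in how those atoms are arranged, and the compounds shown cannot separate the two. Going by these compounds, how a pyridin-2-yl ring, a pyrimidin-2-yl ring or a longer chain in place of the (pyrazin-2-yl)methoxy link would read in this assay remains open.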